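Aryl variation on a flavone series, sigma receptor binding

The source may hold more compounds than are shown below. What is called first, only, known or untested is meant among the compounds shown, and "the series" means these compounds.

Measured compounds:
compound 1 `O=c1cc(-c2cccs2)oc2ccc(OCCCCCCN3CCC(O)CC3)cc12` gives 119 nM in an assay on isolated protein (Cavia porcellus) with Sigma non-opioid intracellular receptor 1 (Homo sapiens) as the target, read by radioligand binding; a higher number here means a weaker inhibitor, a lower number a stronger inhibitor
compound 2 `COc1cccc(-c2cc(=O)c3cc(OCCCCCCN4CCC(O)CC4)ccc3o2)c1` gives 76 nM in this assay
compound 3 `O=c1cc(-c2ccc(F)cc2)oc2ccc(OCCCCCCN3CCC(O)CC3)cc12` gives 95 nM in this assay

The three compounds share one core and differ only in the aromatic group attached to it. Compound 3 sits between the other two on the numbers, but every step among them stays within the scatter: a 1.6-fold lower number from compound 1 to compound 2 (0.19 log units; within the scatter), a 1.3-fold lower number from compound 1 to compound 3 (0.10 log units; within the scatter) and a 1.3-fold higher number from compound 2 to compound 3 (0.10 log units; within the scatter). Nothing here separates thiophen-2-yl, 3-methoxyphenyl and 4-fluorophenyl from one another.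

Compound 4 `COc1ccc(-c2cc(=O)c3cc(OCCCCCCN4CCC(O)CC4)ccc3o2)cc1` is not yet measured. It differs from compound 3 in one place: methoxy in place of fluoro on an aromatic carbon. Within the data shown here, the steps that bear on this are those above, in particular the move from 3-methoxyphenyl to 4-fluorophenyl, which was within the scatter, so the aromatic group appears tolerant of these changes. No step beyond the scatter is therefore expected in this assay for compound 4, estimated at a 1.1-fold lower number from compound 3 to compound 4 (0.05 log units; within the scatter). Compound 4 is expected near 85 nM, within 45 nM to 170 nM.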

Compound 4, half-maximal inhibitory concentration: 254 nM
Beside the measured number, compound 4's estimate is 3.0-fold (0.48 log units) below it; measured number above the stated range.
By their numbers in this assay, from the lowest: compounds 2, 3 and 1 (each within the scatter of the next); then compound 4.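

In this assay, among these compounds, the aromatic group proves less tolerant than the earlier compounds suggested: replacing fluoro with methoxy, para to a large group, gives a 2.7-fold higher number from compound 3 to compound 4 (0.43 log units; beyond the scatter), the first step beyond the scatter. Where the methoxy sits matters, since 4-methoxyphenyl in place of 3-methoxyphenyl gives a 3.3-fold higher number from compound 2 to compound 4 (0.52 log units; beyond the scatter), and the 4-methoxyphenyl group also separates from thiophen-2-yl, with a 2.1-fold higher number from compound 1 to compound 4 (0.33 log units; beyond the scatter), a separation the 3-methoxyphenyl group did not show. No measurement available here accounts for this difference.

On these data alone, it remains open whether a 4-methylphenyl, 4-chlorophenyl or 4-hydroxyphenyl group would stay with compound 3 or fall with compound 4. As far as these compounds go, it is also open whether the fluoro-to-methoxy step would hold with a shorter chain in place of the one on the shared core.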